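Shortening the Ketone Side Chain in a Receptor Modulator Series

A few compounds are considered here, and "the series" means these few. Any claim that something is new, unique, unknown or untested is made for them only; others in the source may bear on it.

Three compounds were measured in an assay on HEK293 cells for positive allosteric modulation of metabotropic glutamate receptor 3 (Rattus norvegicus), read by thallium flux, with a stated time of 2.5 min; a lower number here means a smaller maximal response, a higher number a larger maximal response:

Compound 1, `CCCC(=O)c1ccc(OCCCCOc2cccc(C(=O)O)c2C)c(C)c1O`, gives 53%.
Compound 2, `CCC(=O)c1ccc(OCCCCOc2cccc(C(=O)O)c2C)c(C)c1O`, gives 16.3%.
Compound 3, `CCC(=O)c1ccc(OCCCCOc2ccc(C(=O)O)cc2C)c(C)c1O`, gives 22.7%.

Compound 2 differs from compound 1 only by hydrogen in place of methyl on a saturated chain carbon, two bonds along the chain from a carbonyl carbon, and this change brought a number 36.7 percentage points lower from compound 1 to compound 2 (beyond the scatter). Compound 3 carries a different core from compound 1; the difference between the two cores is not broken down here. Compound 4, `CC(=O)c1ccc(OCCCCOc2ccc(C(=O)O)cc2C)c(C)c1O`, differs from compound 3 by hydrogen in place of methyl on a saturated chain carbon bound to a carbonyl carbon. This is the same kind of change as from compound 1 to compound 2, but not the same: there the carbon sat two bonds along the chain from the carbonyl carbon, here it is bound to the carbonyl carbon. Because the earlier change gave a number 36.7 percentage points lower from compound 1 to compound 2 (beyond the scatter), a fall is expected here as well, though compound 3 already starts low, so the expected step is a number 10.7 percentage points lower from compound 3 to compound 4 (beyond the scatter). For compound 4 in this assay the estimate is 12%, expected to lie between 3% and 30%.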

Compound 4, largest response reached (reported as percent of maximum), in percent of the reference or control that the assay uses: 25.4%
Beside the measured number, compound 4's estimate is 13.4 percentage points below it, within the range that was stated.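

In this assay, going from propanoyl to acetyl gave a number 2.7 percentage points higher from compound 3 to compound 4 (within the scatter), so this shortening does not separate compound 4 from compound 3. A shorter ketone chain therefore did not carry the same effect from one core to the other: the same change on two cores in this assay, a number 36.7 percentage points lower (beyond the scatter) from compound 1 to compound 2 and a number 2.7 percentage points higher (within the scatter) from compound 3 to compound 4, 39.4 percentage points apart, beyond the scatter of two such steps This does not show why the steps differ, since the change also sits at a different place on the chain in each pair, and one pair per core cannot separate the role of the core from that of the place.

The compounds shown leave open what a longer chain on the ketone would give on the core of compound 3. They also leave open how an amide in place of the carboxylic acid would behave on either core.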